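The compounds below may be only part of what the source reports. "The series", "measured", "known", "first", "only" and "open" are said of these compounds alone.

Of the compounds shown here, three of one shared core have been measured in a functional assay on HEK293 cells for agonist activity at trace amine-associated receptor 1 (Homo sapiens), read by cAMP accumulation, with a stated time of 30 min; a higher number here means a larger maximal response, a lower number a smaller maximal response. Compound 1, `Cc1ccccc1[C@H]1COC(N)=N1`, reaches 78% in this assay. Compound 2, `Cc1cc(Cl)ccc1[C@H]1COC(N)=N1`, differs from compound 1 by chloro in place of hydrogen on an aromatic carbon, and in this assay compound 2 gives 78%, so that no change at the digits printed from compound 1 to compound 2 (within the scatter). Compound 3, `NC1=N[C@@H](c2ccccc2)CO1`, differs from compound 1 by hydrogen in place of methyl on an aromatic carbon, and in this assay compound 3 gives 104%, which is a number 26 percentage points higher from compound 1 to compound 3 (beyond the scatter).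

Compound 4, `NC1=N[C@@H](c2ccccc2Cl)CO1`, has not yet been measured. It differs from compound 3 by chloro in place of hydrogen on an aromatic carbon. Among the measured compounds shown here, this is the same kind of change as the one from compound 1 to compound 2, but not the same: there the chloro entered meta to a methyl group and para to a group of 6 heavy atoms, here it enters ortho to a group of 6 heavy atoms. The earlier chloro step left the value unchanged within the scatter, so the expected step of a number 16 percentage points lower from compound 3 to compound 4 (beyond the scatter) is small, tempered by the larger value of compound 3 and the different place of the chloro. The estimate for compound 4 is 88%, expected between 68% and 108%.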

Compound 4, largest response reached (Emax), in percent of the reference or control that the assay uses: 100%
Beside the measured number, compound 4's estimate is 12 percentage points below it; the range from low to high includes it.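

In this assay, chloro in place of hydrogen on an aromatic carbon gives a number 4 percentage points lower from compound 3 to compound 4 (within the scatter), and set beside the same change on the other core, the two steps agree: the same change on two cores in this assay, no change at the digits printed (within the scatter) from compound 1 to compound 2 and a number 4 percentage points lower (within the scatter) from compound 3 to compound 4, 4 percentage points apart, within the scatter of two such steps. Chloro in place of methyl on an aromatic carbon is a different change and gives a number 22 percentage points higher from compound 1 to compound 4 (beyond the scatter), so in this pair the two groups do not read alike. Two pairs show that the chloro change carried over here without a step beyond the scatter, but they do not make a general rule, as the chloro sits at a different place on the ring in each pair and other cores may behave differently.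

The compounds shown leave open how other groups at the same place on the ring, such as a methoxy group, an amine or a carboxylic acid, would compare with chloro. They also leave open whether a fluoro or bromo group would follow the chloro steps, and a largest response says nothing about the concentration needed to reach it.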